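Naphthalen-1-yl to 4-chlorophenyl on the shared core

This account rests on a few compounds, and the source may have more. Where it says the series, first, only, none or still open, it means among the compounds named here.

In a functional assay on THP-1 cells (Homo sapiens) for inhibition, read by sulforhodamine B assay, tested at 10 uM (a lower number here means less inhibition of growth, a higher number more inhibition of growth at the concentration tested), compound 1 `COc1cc(C2CC(c3cccc4ccccc34)=NN2C(C)=O)ccc1OCc1cn(Cc2ccc([N+](=O)[O-])cc2)nn1` gives 10%, with compound 2 `COc1ccc(C2=NN(C(C)=O)C(c3ccc(OCc4cn(Cc5ccc([N+](=O)[O-])cc5)nn4)c(OC)c3)C2)cc1` at 8% lying within the scatter of it. The step of a number 2 percentage points lower from compound 1 to compound 2 (within the scatter) stayed within the scatter. Compound 3 `COc1cc(C2CC(c3ccc(Cl)cc3)=NN2C(C)=O)ccc1OCc1cn(Cc2ccc([N+](=O)[O-])cc2)nn1` differs from compound 1 by 4-chlorophenyl in place of naphthalen-1-yl on a carbon with a double bond to nitrogen. For the measured compounds named here, the one step that bears on this change, a number 2 percentage points lower from compound 1 to compound 2 (within the scatter), also replaced the naphthalen-1-yl with one six-membered aromatic ring of carbon only at the same place. No step beyond the scatter is therefore expected, a number 1 percentage points lower from compound 1 to compound 3 (within the scatter). Compound 3 is estimated at 9%, between 0% and 20%.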

Compound 3, percent growth inhibition at one concentration: 17%
Compound 3: the middle estimate sits 8 percentage points below what was measured, within the range that was stated.
By their numbers in this assay, from the lowest: compounds 2, 1 and 3 (each within the scatter of the next).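

With 4-chlorophenyl in place of naphthalen-1-yl, a number 7 percentage points higher from compound 1 to compound 3 (within the scatter) is the result, and chloro in place of methoxy on an aromatic carbon gives a number 9 percentage points higher from compound 2 to compound 3 (within the scatter) in this series. In this assay, these three aromatic groups on the carbon with a double bond to nitrogen are therefore not separated, whether one ring or two are present. No measurement at hand bears on the cause of these small steps.

Open, on these data alone, is whether an amine, a carboxylic acid or a longer alkyl chain at this carbon would move the number beyond the scatter in this assay at all.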